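Acylsulfonylhydrazide series: removing the acetamido group

The compounds below may be only part of what the source reports. "The series", "measured", "known", "first", "only" and "open" are said of these compounds alone.

Measured so far in an assay on HeLa cells for inhibition of Indoleamine 2,3-dioxygenase 1 (Homo sapiens), read by spectrophotometry, with a stated time of 24 h; a lower number here means that less compound is needed, a higher number that more compound is needed for the effect:
compound 1 `CC(=O)Nc1ccc(S(=O)(=O)NNc2ccc(Br)cc2)cc1` gives 85 nM
compound 2 `CC(=O)Nc1ccc(S(=O)(=O)NNc2cccc(Br)c2)cc1` gives 7560 nM

Going by the values given here, compound 1 has the lowest number of the two; its nearest neighbour is compound 2, and the single step between them, an 89-fold higher number from compound 1 to compound 2 (1.95 log units; beyond the scatter), follows from putting 3-bromophenyl in place of 4-bromophenyl on an amine nitrogen.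

The next compound, compound 3 `O=S(=O)(NNc1ccc(Br)cc1)c1ccccc1`, differs from compound 1 at the other ring: hydrogen in place of acetamido on an aromatic carbon, at the site described as para to a large group. Among the compounds with values here, no measured step touches this part of the molecule; the only step on record concerns the bromine-bearing ring, and it shows the series is sensitive to a change of substituent position there. That gives no direct guidance on loss of the acetamido group, so the expectation rests on the change itself and on compound 1 as the starting point.

The working expectation is a moderate rise in the number, a 3.5-fold higher number from compound 1 to compound 3 (0.55 log units; beyond the scatter), with wide uncertainty in both directions. For compound 3 the estimate in this assay is 300 nM, within 60 nM to 1500 nM.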

Compound 3, half-maximal effective concentration: 128 nM
The estimate for compound 3 lay 2.3-fold (0.37 log units) above the measured number, within the range that was stated.
By their numbers in this assay, from the lowest: compounds 1 and 3 (each within the scatter of the next); then compound 2.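

Replacing the acetamido group with hydrogen, para to a large group, gives a 1.5-fold higher number from compound 1 to compound 3 (0.18 log units; within the scatter) in this assay and so leaves compound 1 and compound 3 indistinguishable, even though the hydrogen-bond donor and acceptor of the acetamido group are gone. The acetamido group is therefore not required at this position for a number of this order, whereas the change on the bromine-bearing ring, an 89-fold higher number from compound 1 to compound 2 (1.95 log units; beyond the scatter), stands beyond the scatter, so among these three compounds the only large step lies on that ring. No measurement at hand bears on why this change and the bromine shift differ so much in size.

Still open, going by these compounds, is whether this position accepts substituents generally or only these two: an amine, a carboxylic acid, a methoxy group or a longer acyl chain in the same place could give a quite different number. Also open, on these data alone, is whether the large step on the bromine-bearing ring holds without the acetamido group, and whether chlorine or methyl can stand in for the bromine of compound 3.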